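Fluoro in Place of Methyl: What to Expect for Compound 4

The source may hold more compounds than are shown below. What is called first, only, known or untested is meant among the compounds shown, and "the series" means these compounds.

Measured so far:
compound 1, `Cc1ccc(C[C@H]2COC(=O)[C@@H]2Cc2ccc(Cl)c(Cl)c2)cc1`: 19000 nM
compound 2, `O=C1OC[C@H](Cc2ccc(F)cc2)[C@H]1Cc1ccc(Cl)c(Cl)c1`: 14000 nM
compound 3, `Cc1cccc(C[C@H]2COC[C@@H]2Cc2ccc(Cl)c(Cl)c2)c1`: 28000 nM

These values come from a functional assay on HL-60 cells (Homo sapiens) for cytotoxicity, read by WST assay, with a stated time of 48 h; a higher number here means that more compound is needed for the effect, a lower number that less compound is needed. Compound 1 and compound 2 differ in one place, (fluoro in place of methyl on an aromatic carbon), and the step was a 1.4-fold lower number from compound 1 to compound 2 (0.13 log units; within the scatter). Compound 4, `Fc1cccc(C[C@H]2COC[C@@H]2Cc2ccc(Cl)c(Cl)c2)c1`, has not been measured in this assay; it differs from compound 3 by fluoro in place of methyl on an aromatic carbon. This is the same kind of change as from compound 1 to compound 2, though the place differs: there the fluoro sits para to a large group, here meta to a large group. The difference between the core of compound 1 and the core of compound 3 is not broken down here. The step from compound 3 to compound 4 is expected to be small, a 1.3-fold lower number from compound 3 to compound 4 (0.10 log units; within the scatter), because the same kind of change gave only a 1.4-fold lower number from compound 1 to compound 2 (0.13 log units; within the scatter). Compound 4 is therefore estimated at 22000 nM, between 9000 nM and 50000 nM.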

Compound 4, half-maximal effective concentration: 20000 nM
Compound 4: the middle estimate sits 1.1-fold (0.04 log units) above what was measured; measured number inside the range.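

In this assay, swapping methyl for fluoro again makes little difference: a 1.4-fold lower number from compound 3 to compound 4 (0.15 log units; within the scatter). The change therefore gives closely matching results on the two cores: the same change on two cores in this assay, a 1.4-fold lower number (0.13 log units; within the scatter) from compound 1 to compound 2 and a 1.4-fold lower number (0.15 log units; within the scatter) from compound 3 to compound 4, 1.0-fold (0.01 log units) apart, within the scatter of two such steps. For the compounds shown here, this agreement does not show that fluoro truly lowers the number, as each step lies within the scatter, and it covers only two cores, with the fluoro in a different place on each.

The compounds shown carry only methyl or fluoro at the changed position, so it remains open how an amine, a carboxylic acid or a longer chain would behave there. Also open, on these data alone, is whether any change at that position would give a step beyond the scatter.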